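From fluoro to pyridin-3-yl in the series

The source may report more compounds than this note shows. Statements on the series, on what has been measured and on what is new or still open speak of the compounds shown alone.

In a functional assay on KG-1 cells (Homo sapiens) for cytotoxicity, read by luminescence and CellTiter-Glo, with a stated time of 3 days (on this read-out higher numbers stand for weaker inhibition and lower numbers for stronger inhibition), compound 1 (`COc1ccc(O)c(C(=O)Nc2ccc(C#N)cc2)c1`) reports > 10000 nM as a limit of the assay. Compound 2 (`N#Cc1ccc(NC(=O)c2cc(-c3ccccc3)ccc2O)cc1`) gives 1300 nM in this read-out. Compound 3 (`N#Cc1ccc(NC(=O)c2cc(F)ccc2O)cc1`) gives 2670 nM here, the higher of the two actual numbers. Compound 4 (`N#Cc1ccc(NC(=O)c2cc(-c3cccnc3)ccc2O)cc1`) carries pyridin-3-yl in place of fluoro on an aromatic carbon. The closest guide is the phenyl group of compound 2, with a 2.1-fold higher number from compound 2 to compound 3 (0.31 log units; beyond the scatter) on losing that ring. The steps of an at least 7.6-fold lower number from compound 1 to compound 2 (0.88 log units; beyond the scatter) and an at least 3.7-fold lower number from compound 1 to compound 3 (0.57 log units; beyond the scatter) start from the limit and only bound the effect. The expected change is a 1.9-fold lower number from compound 3 to compound 4 (0.28 log units; within the scatter) in this assay, a modest move to a lower number. For compound 4 the estimated value is 1400 nM with an expected range of 500 nM to 4000 nM in this assay.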

Compound 4, half-maximal inhibitory concentration: 8330 nM
Estimate against measurement, compound 4: 6.0-fold (0.77 log units) below, outside the stated range (above it).
By their numbers in this assay, from the lowest: compound 2; then compound 3; then compound 4. At a limit, above all of these: compound 1.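

In this assay pyridin-3-yl in place of phenyl, para to a hydroxy group, gives as a modest step of a 6.4-fold higher number from compound 2 to compound 4 (0.81 log units; beyond the scatter) with one hetero atom as the difference in the ring. Pyridin-3-yl in place of fluoro gives a 3.1-fold higher number from compound 3 to compound 4 (0.49 log units; beyond the scatter) and shows that an aromatic ring here does not in itself lower the number, as compound 2 alone might have suggested. Compound 1 stands at a limit. The step of an at least 1.2-fold lower number from compound 1 to compound 4 (0.07 log units; that floor lies within the scatter) therefore gives only a floor, and that floor lies within the scatter: the limit of > 10000 nM in this assay, at which 1 of the 4 values shown sits.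

The compounds shown leave open how pyridin-4-yl would read at this position. Phenyl carrying an amine or a carboxylic acid is equally open.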